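This account rests on a few compounds, and the source may have more. Where it says the series, first, only, none or still open, it means among the compounds named here.

Of the compounds shown here, two have been measured so far in a functional assay on A549 cells (Homo sapiens) for antiproliferative activity, read by MTT assay, with a stated time of 24 h; a higher number here means a weaker inhibitor, a lower number a stronger inhibitor. Compound 1 `Cc1cccc(-n2cc(-c3ccccc3NS(=O)(=O)c3c[nH]c(=O)[nH]c3=O)nn2)c1` gives 1870 nM in this assay. Compound 2 `Cc1ccc(-n2cc(-c3ccccc3NS(=O)(=O)c3c[nH]c(=O)[nH]c3=O)nn2)cc1` gives 2910 nM in this assay. These two differ only in 4-methylphenyl standing in place of 3-methylphenyl on an aromatic nitrogen, and the step of a 1.6-fold higher number from compound 1 to compound 2 (0.19 log units; within the scatter) lies within the scatter, so the two numbers cannot be told apart. Compound 2 holds the higher of the two numbers, but that order carries no weight on its own.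

Compound 3 `O=c1[nH]cc(S(=O)(=O)Nc2ccccc2-c2cn(-c3ccc(F)cc3)nn2)c(=O)[nH]1` has not yet been measured. It differs from compound 2 by fluoro in place of methyl on an aromatic carbon, which taken one bond further out reads 4-methylphenyl to 4-fluorophenyl. For the measured compounds named here, no measured step exchanges methyl for fluoro, so the only guide is the neighbouring step a 1.6-fold higher number from compound 1 to compound 2 (0.19 log units; within the scatter), a small move within the scatter after a change on the same ring. On that basis the expected step in this assay is none beyond the scatter, a 1.0-fold lower number from compound 2 to compound 3 (0.00 log units; within the scatter). Compound 3 is therefore estimated at 2900 nM in this assay, with a range from 1200 nM to 7000 nM.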

Compound 3, half-maximal inhibitory concentration: 6390 nM
Compound 3: middle estimate off by 2.2-fold (0.34 log units), on the low side; the range from low to high includes it.
By their numbers in this assay, from the lowest: compounds 1 and 2 (each within the scatter of the next); then compound 3.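

In this assay, replacing methyl with fluoro on this aromatic carbon para to a large group gives a 2.2-fold higher number from compound 2 to compound 3 (0.34 log units; beyond the scatter) and so produces the first difference in this small set that can be told apart from assay noise, though it is only modest. The comparison with the other methyl compound points the same way, with a 3.4-fold higher number from compound 1 to compound 3 (0.53 log units; beyond the scatter) for the change from 3-methylphenyl to 4-fluorophenyl, so compound 3 stands apart as the weakest of the three, while compounds 1 and 2 remain indistinguishable. Nothing shown here explains why this exchange weakens the antiproliferative effect.

With only methyl and fluoro at this ring, a single exchange cannot show whether the loss belongs to fluoro in particular or whether methyl is simply better than the alternatives. A chloro, methoxy or amino group in the same place, or a plain unsubstituted phenyl, would help show whether compound 3 is an isolated case or part of a wider trend.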